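Small alkyl swap on a ring nitrogen of the shared core

The source may report more compounds than this note shows. Statements on the series, on what has been measured and on what is new or still open speak of the compounds shown alone.

Compound 2 `Cc1ccc(Nc2ncc3c(n2)N(C2CC2)C(=O)N(c2cc(NC(=O)c4ccc(C)c(C(F)(F)F)c4)ccc2C)C3)cn1` was tested in an ADME assay on BaF3 cells (Mus musculus) for inhibition, read by CellTiter-Glo, with a stated time of 72 h (on this read-out lower numbers stand for stronger inhibition of growth and higher numbers for weaker inhibition of growth), where compound 2 gives 649 nM. Two close relatives share its core. Compound 1 `CCN1CCN(C(=O)c2ccc(Nc3ncc4c(n3)N(C)C(=O)N(c3cc(NC(=O)c5ccc(CN6CCC(N(C)C)C6)c(C(F)(F)F)c5)ccc3C)C4)cn2)CC1` gives 704 nM in this assay, and compound 3 `CCN1CCN(C(=O)c2ccc(Nc3ncc4c(n3)N(C)C(=O)N(c3cc(NC(=O)c5cccc(C(F)(F)F)c5)ccc3C)C4)cn2)CC1` gives 728 nM. All three numbers sit within the usual scatter of one another, so none of the three can be set apart from the others on these data.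

Going by the values given here, the only step between measured compounds is the one from compound 1 to compound 3, a 1.0-fold higher number from compound 1 to compound 3 (0.01 log units; within the scatter), which concerns a group on an aromatic carbon and lies within the scatter.

Compound 4 `CCN1C(=O)N(c2cc(NC(=O)c3ccc(C)c(C(F)(F)F)c3)ccc2C)Cc2cnc(Nc3ccc(C)nc3)nc21` has not yet been measured. It differs from compound 2 in one place: ethyl in place of cyclopropyl on an amide-type nitrogen in a ring. Among the compounds with values here, no measured pair changes a group at this ring nitrogen, so the change from compound 1 to compound 3 bears only loosely on it, and it showed no shift beyond the scatter. For this assay the expected step is therefore a 1.0-fold higher number from compound 2 to compound 4 (0.00 log units; within the scatter), with no move beyond the scatter anticipated in either direction. Compound 4 is estimated at 650 nM, within a range from 300 nM to 1400 nM.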

Compound 4, concentration for 50% growth inhibition: 708 nM
Compound 4: the middle estimate sits 1.1-fold (0.04 log units) below what was measured; the range from low to high includes it.
By their numbers in this assay, from the lowest: compounds 2, 1, 4 and 3 (each within the scatter of the next).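

In this assay, going by these compounds alone, putting ethyl in place of cyclopropyl on the amide-type nitrogen in a ring gives a 1.1-fold higher number from compound 2 to compound 4 (0.04 log units; within the scatter), and this is the first measured pair in which the group on this nitrogen changes. On the background of compound 2, then, a three-membered ring of 3 heavy atoms and an open group of 2 heavy atoms cannot be told apart by this read-out, so neither the ring nor the third carbon shows a measurable effect on growth inhibition here. No measurement at hand offers a reason for this result.

This is a single pair on a single background, and both groups are small and made only of carbon, so it does not show how far this nitrogen tolerates change, or whether the same would hold with the other substituents found on the shared core. A longer chain such as n-butyl, or a chain ending in an amine or a hydroxyl group, would test whether anything placed on this nitrogen can move the number beyond the scatter, in either direction.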